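A few compounds are considered here, and "the series" means these few. Any claim that something is new, unique, unknown or untested is made for them only; others in the source may bear on it.

Going by the values given here, in a functional assay on MDA-MB-231 cells (Homo sapiens) for antiproliferative activity, read by CCK-8 assay, with a stated time of 72 h (on this read-out higher numbers stand for weaker inhibition and lower numbers for stronger inhibition), compound 1 `COc1cccc(OC)c1C(=O)Nc1ccc(C(=O)/C=C/c2nc(C)c(C)nc2C)cc1` gives 3850 nM and holds the higher of the two numbers so far, with compound 2 `Cc1ccc(C(=O)Nc2ccc(C(=O)/C=C/c3nc(C)c(C)nc3C)cc2)cc1` at 1780 nM in the same read-out. Compound 3 `COc1ccc(C(=O)Nc2ccc(C(=O)/C=C/c3nc(C)c(C)nc3C)cc2)cc1` is not yet measured and differs from compound 1 on a carbonyl carbon as follows: 4-methoxyphenyl in place of 2,6-dimethoxyphenyl on a carbonyl carbon (4-methoxyphenyl in place of 2,6-dimethoxyphenyl). Among the compounds with values here, the one measured step bearing on this is a 2.2-fold lower number from compound 1 to compound 2 (0.34 log units; beyond the scatter) and it is modest, with 4-methylphenyl entering on that carbonyl carbon. A step of similar size towards a lower number is therefore expected in this assay for compound 3. The estimate for compound 3 is 1800 nM with an expected range of 800 nM to 4000 nM and this estimated move is a 2.1-fold lower number from compound 1 to compound 3 (0.33 log units; beyond the scatter) in size.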

Compound 3, half-maximal inhibitory concentration: 1600 nM
The estimate for compound 3 lay 1.1-fold (0.05 log units) above the measured number; the range from low to high includes it.
By their numbers in this assay, from the lowest: compounds 3 and 2 (each within the scatter of the next); then compound 1.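

In this assay, going by these compounds alone, 4-methoxyphenyl in place of 2,6-dimethoxyphenyl on the carbonyl carbon gives a 2.4-fold lower number from compound 1 to compound 3 (0.38 log units; beyond the scatter), so the 4-methylphenyl of compound 2 is no longer the only group to stand apart from compound 1. Methoxy in place of methyl on an aromatic carbon gives a 1.1-fold lower number from compound 2 to compound 3 (0.05 log units; within the scatter), so this read-out does not tell these two groups apart. No measurement on hand gives a cause for either step. The compounds shown leave open whether the number for compound 1 follows from carrying two methoxy groups or from where they stand. On these data alone, how a fluoro, a dimethylamino or a carboxylic acid group on that aromatic ring would read also stays open.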